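The compounds below may be only part of what the source reports. "The series", "measured", "known", "first", "only" and "open" are said of these compounds alone.

Measured compounds in a functional assay on isolated protein for inhibition of Glucose-dependent insulinotropic receptor (Rattus norvegicus), read by HTRF and cAMP accumulation; on this read-out lower numbers stand for smaller maximal responses and higher numbers for larger maximal responses:
compound 1, `Cc1nc(S(C)(=O)=O)ccc1Oc1ncnc(OC2CCN(C(=O)O[C@H](C)CF)CC2)c1F`, gives 79%
compound 2, `Cc1nc(S(C)(=O)=O)ccc1Oc1ncnc(OC2CCN(C(=S)OC3(C)CC3)CC2)c1F`, gives 49%

Compound 2 stands at the lower of the two values; its nearest neighbour is compound 1, and the step of a number 30 percentage points lower from compound 1 to compound 2 (beyond the scatter) separates them.

Compound 3, `CCc1cnc(C(=O)N2CCC(Oc3ncnc(Oc4ccc(S(C)(=O)=O)nc4C)c3F)CC2)nc1`, has not been measured in this assay. It differs from compound 2 by a group of 10 heavy atoms (7 carbon, 2 nitrogen, 1 oxygen; one six-membered aromatic ring with 2 hetero atoms) in place of a group of 7 heavy atoms (5 carbon, 1 oxygen, 1 sulfur; one three-membered non-aromatic ring of carbon only), on an amine nitrogen in a ring.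

Going by the values given here, only one measured step exists, a number 30 percentage points lower from compound 1 to compound 2 (beyond the scatter), and it bears on the step to compound 3 only indirectly: it shows that an exchange on the amine nitrogen in a ring can move the response by a modest amount beyond the scatter, with the group carrying the three-membered ring giving the lower value. The group entering in compound 3 resembles neither the group leaving nor the group in compound 1, so the direction is uncertain. A return toward the value of compound 1 is expected as the more likely outcome, with the step of a number 21 percentage points higher from compound 2 to compound 3 (beyond the scatter) estimated. For compound 3 the estimate in this assay is 70%, between 45% and 95%.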

Compound 3, largest response reached (reported as efficacy), in percent of the reference or control that the assay uses: 80%
For compound 3 the middle estimate is 10 percentage points below the measured one; the range from low to high includes it.
By their numbers in this assay, from the lowest: compound 2; then compounds 1 and 3 (each within the scatter of the next).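

In this assay, the amine nitrogen in a ring carries a six-membered aromatic ring with 2 hetero atoms, attached through a carbonyl, and exchanging the group with the three-membered ring for it gives a number 31 percentage points higher from compound 2 to compound 3 (beyond the scatter). The earlier pair showed only a fall in maximal response at this position, whereas this step shows a rise and that a high response does not depend on a group without a ring: on the carbonyl carbon, the aromatic group in place of the fluorine-bearing group gives a number 1 percentage points higher from compound 1 to compound 3 (within the scatter). No available measurement bears on the cause of these steps. As far as these compounds go, whether a plain phenyl ring would give a similar response remains open, as does the effect of a carboxylic acid on the aromatic ring. Going by these compounds alone, with only one compound of each type, the values establish no general pattern.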